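This account rests on a few compounds, and the source may have more. Where it says the series, first, only, none or still open, it means among the compounds named here.

Measured so far in an in vitro ADME assay on microsomes (Homo sapiens) for metabolic stability; a lower number here means slower removal, a higher number faster removal of the compound:
- compound 1 `O=C(CN(CC1CC1)C(=O)c1ccc(-c2ccccn2)cc1)Nc1cc(F)cc(F)c1`: < 0.5 mL.min-1.g-1
- compound 2 `O=C(CN(C(=O)c1ccc(-c2ccccn2)cc1)C1CCCOC1)Nc1cc(F)cc(F)c1`: 2.9 mL.min-1.g-1

Compound 1 gives only a limit of the assay, < 0.5 mL.min-1.g-1. Among the measured compounds shown here, compound 2 therefore holds the only actual number, 2.9 mL.min-1.g-1, and there is no wider range of numbers against which to place it.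

Compound 3 `O=C(CN(C(=O)c1ccc(-c2ccccn2)cc1)C1CCOCC1)Nc1cc(F)cc(F)c1` has the same atoms as compound 2, joined differently: oxan-4-yl in place of oxan-3-yl on an amide-type nitrogen. The change is oxan-4-yl in place of oxan-3-yl on an amide-type nitrogen.

For the measured compounds named here, only one measured step bears on this, an at least 5.8-fold higher number from compound 1 to compound 2 (0.76 log units; beyond the scatter). It lies beyond the scatter and is at least modest, but it replaces cyclopropylmethyl with oxan-3-yl. Going by the values given here, it shows that the group on this nitrogen can matter in this assay, yet no measured pair compares oxan-3-yl with oxan-4-yl. No direction can be drawn from it, so the working expectation is no change beyond the scatter, with a wide range.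

The expected step, a 1.2-fold lower number from compound 2 to compound 3 (0.06 log units; within the scatter), is an estimate that stays within the scatter. For compound 3 the estimated value is 2.5 mL.min-1.g-1, with an expected range from 1 mL.min-1.g-1 to 6 mL.min-1.g-1.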

Compound 3, intrinsic clearance in microsomes: < 0.5 mL.min-1.g-1
Compound 3: no number, only a limit; the forecaster's own chance of this, stated with the estimate: 10%; middle value at least 5.0-fold (0.69 log units) away from the limit.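

In this assay, exchanging oxan-3-yl for oxan-4-yl on the amide-type nitrogen gives an at least 5.8-fold lower number from compound 2 to compound 3 (0.76 log units; beyond the scatter). Compound 3 gives only a limit of the assay, < 0.5 mL.min-1.g-1, so the size of this step has a lower bound but no upper one. The earlier step showed only that replacing cyclopropylmethyl with oxan-3-yl at this position can matter, whereas this pair has the same atoms joined differently and shows that the way the ring is attached is enough to produce a change beyond the scatter.

From the compounds shown here alone, how oxan-4-yl compares with cyclopropylmethyl stays hidden, and the step from compound 1 to compound 3 cannot be read, as both compounds sit at the same limit: the limit of < 0.5 mL.min-1.g-1 in this assay, at which 2 of the 3 values shown sit. Also open is whether an amine such as piperidin-4-yl, or a longer chain such as cyclobutylmethyl, on the same nitrogen would stay at that limit or give a readable number closer to that of compound 2.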